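This account rests on a few compounds, and the source may have more. Where it says the series, first, only, none or still open, it means among the compounds named here.

Three compounds built on the same core were tested in an ADME assay on Vero cells (Chlorocebus sabaeus) for cytotoxicity, read by neutral red uptake, tested at 12.3 ug/mL; a lower number here means a stronger effect, a higher number a weaker effect of the compound at the concentration tested. Compound 1 `O=C1CSC(c2ccc(F)cc2)N1CCN1CCCCC1` gives 100%. Compound 2 `COc1cccc(C2SCC(=O)N2CCN2CCCCC2)c1` gives 100%, and compound 3 `O=C1CSC(c2ccccc2[N+](=O)[O-])N1CCN1CCCCC1` gives 100%. At the digits shown, compound 1 stands level with compound 2 and with compound 3; the gaps lie within the scatter of this assay, so no order among the three can be read from these numbers.

The next compound, compound 4 `Cc1ccc(C2SCC(=O)N2CCN2CCCCC2)cc1`, differs from compound 1 in one place: methyl in place of fluoro on an aromatic carbon. Given that every compound so far sits at the same level, the step of a number 2 percentage points lower from compound 1 to compound 4 (within the scatter) is expected to be none beyond the scatter. Compound 4 is therefore estimated at 98%, with a range from 85% to 100%.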

Compound 4, a percentage reported as activity, at one concentration (the size of the read-out at that concentration, not a potency): 100%
Compound 4: the middle estimate sits 2 percentage points below what was measured; low and high end bracket the measured number.
By their numbers in this assay, from the lowest: compounds 1, 2, 3 and 4 (each within the scatter of the next).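

Methyl in place of fluoro on an aromatic carbon, para to a large group, gives in this assay no change at the digits printed from compound 1 to compound 4 (within the scatter). Within the data shown here, this is the first comparison in the set that isolates a single position, and at the concentration tested the read-out does not separate these two groups there. No available evidence bears on this result.

Going by these compounds, whether an amine or a carboxylic acid at this same position would hold the read-out at this level remains open. The same question stands for a longer chain in place of the methyl.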